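The source may hold more compounds than are shown below. What is called first, only, known or untested is meant among the compounds shown, and "the series" means these compounds.

The measured compounds in this study:
Compound 1 `CCN1CCc2c(c(C)nn2C(=O)Nc2ccc(C)cc2C)C1`; in a functional assay on the whole organism (strain Swiss albino) for inhibition, with Mus musculus as the target, in the formalin test, with a stated time of 30 min, at a dose of 100 mg/kg (a lower number here means less inhibition, a higher number more inhibition at the dose given (going by the name of the read-out)), compound 1 gives 16.3%.
Compound 2 `CCN1CCc2c(c(C)nn2C(=O)Nc2ccc(Cl)cc2)C1`; in this assay compound 2 gives 7.5%.
Compound 3 `CCN1CCc2c(c(C(C)(C)C)nn2C(=O)Nc2cccc(C(F)(F)F)c2)C1`; in this assay compound 3 gives 55.1%.

Compound 2 has the lowest number of the three. Its nearest neighbour is compound 1, whose value lies within the scatter of that of compound 2, so the two are not told apart by this assay. Compound 3, by contrast, lies well beyond the scatter above compound 2 and is the only one of the three with a clearly larger inhibition.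

The step under consideration leads from compound 2 to compound 4 `CCN1CCc2c(c(C(C)(C)C)nn2C(=O)Nc2ccc(Cl)cc2)C1`. The change is tert-butyl in place of methyl on an aromatic carbon. Within the data shown here, no measured pair isolates this change, so its size is not known from the data. Compound 3, which also carries the tert-butyl group though with a different aromatic amine, shows the largest inhibition, which is taken as a hint that the step from compound 2 to compound 4 may go upward. The step from compound 2 to compound 4 is expected to be a number 22.5 percentage points higher from compound 2 to compound 4 (beyond the scatter), an increase beyond the scatter. Compound 4 is estimated to give 30%, with a range from 10% to 55%.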

Compound 4, a percentage reported as inhibition, in the whole organism at one dose (the size of the read-out at that dose, not a potency): 68.3%
For compound 4 the middle estimate is 38.3 percentage points below the measured one, and the stated range ends below it.
By their numbers in this assay, from the lowest: compounds 2 and 1 (each within the scatter of the next); then compound 3; then compound 4.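

In this assay, among these compounds, the change reads as a number 60.8 percentage points higher from compound 2 to compound 4 (beyond the scatter) and gives the first pair in which tert-butyl in place of methyl stands alone, with nothing else in the structure altered. The earlier compounds shown here could not separate this position from the aromatic amine, whereas this pair shows that the aromatic carbon of the five-membered ring is by itself a place where the read-out moves strongly, at least with the chlorine-bearing aromatic amine. Nothing measured here accounts for the size of this step.

The compounds shown leave open how an ethyl or isopropyl group, or a carboxylic acid, on this same carbon would read. As far as these compounds go, whether the change keeps its size with another aromatic amine also stays open, as this single pair is all that isolates it.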